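The compounds below may be only part of what the source reports. "The series", "measured", "known", "first", "only" and "open" are said of these compounds alone.

Working notes on the series. Compound 1 `O=C(NCc1ccc(C(F)(F)F)nc1N1CCCC1)Nc1cccc2[nH]c(=O)ccc12` is the reference of this set; in an assay on HEK cells for antagonist activity at transient receptor potential cation channel subfamily V member 1 (Homo sapiens), read by FLIPR (on this read-out lower numbers stand for stronger inhibition and higher numbers for weaker inhibition), compound 1 gives 0.94 nM. Compound 2 `CCCCCOc1nc(C(F)(F)F)ccc1CNC(=O)Nc1cccc2[nH]c(=O)ccc12` gives 2.72 nM, and compound 3 `CCCCCCOc1nc(C(F)(F)F)ccc1CNC(=O)Nc1cccc2[nH]c(=O)ccc12` gives 3.19 nM. Compound 3 therefore holds the highest number of the three, but the step of a 1.2-fold higher number from compound 2 to compound 3 (0.07 log units; within the scatter) lies within the scatter, so these two compounds cannot be ordered; only compound 1 is clearly apart, with a 3.4-fold higher number from compound 1 to compound 3 (0.53 log units; beyond the scatter) and a 2.9-fold higher number from compound 1 to compound 2 (0.46 log units; beyond the scatter) marking the two alkoxy analogues as modestly weaker.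

The next compound, compound 4 `O=C(NCc1ccc(C(F)(F)F)nc1OCc1ccccc1)Nc1cccc2[nH]c(=O)ccc12`, carries a change at the chain: phenyl in place of pentyl on a saturated chain carbon bound to an oxygen on an aromatic ring. Within the data shown here, no measured step covers this exchange directly. Among the measured compounds shown here, the only step at the same position, a 1.2-fold higher number from compound 2 to compound 3 (0.07 log units; within the scatter), shows that lengthening the chain by one carbon moves nothing beyond the scatter, and both alkoxy chains sit close together relative to compound 1. The replacement of the pentyl by a phenyl is a larger alteration than that step, so some movement is possible, but the data give no direction for it.

On that basis the expected change a 1.1-fold higher number from compound 3 to compound 4 (0.04 log units; within the scatter) from compound 3 to compound 4 is small and likely within the scatter. Compound 4 is estimated at 3.5 nM in this assay, with a range of 1 nM to 12 nM.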

Compound 4, half-maximal inhibitory concentration: 1.2 nM
The estimate for compound 4 lay 2.9-fold (0.46 log units) above the measured number, and the stated range covers the measured number.
By their numbers in this assay, from the lowest: compounds 1 and 4 (each within the scatter of the next); then compounds 2 and 3 (each within the scatter of the next).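

Among these compounds, the swap of the alkyl end of the chain for phenyl is the first change at this position to move the number beyond the scatter in this assay: a 2.7-fold lower number from compound 3 to compound 4 (0.42 log units; beyond the scatter) and a 2.3-fold lower number from compound 2 to compound 4 (0.36 log units; beyond the scatter), set against a 1.2-fold higher number from compound 2 to compound 3 (0.07 log units; within the scatter), where one more carbon in the chain moved nothing beyond the scatter. Benzyloxy also stands level with the pyrrolidin-1-yl reference, with a 1.3-fold higher number from compound 1 to compound 4 (0.11 log units; within the scatter), so compound 4 goes against any reading in which an oxygen at this place comes with the modestly weaker numbers of compounds 2 and 3. No measurement at hand accounts for this shift.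

The compounds shown leave open whether cyclohexylmethoxy, with a saturated ring in place of the phenyl, would read with compound 4 or with compounds 2 and 3, and where a shorter chain such as ethoxy would fall. Also open, on these data alone, is how a chlorine or a methoxy group on the phenyl, or a pyridyl ring in its place, would change the number.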